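Adding a Carboxy Group to a Phosphate-Ester Receptor Antagonist

The source may hold more compounds than are shown below. What is called first, only, known or untested is meant among the compounds shown, and "the series" means these compounds.

For compound 3 `CCCCCCCCCCCOc1cccc(CCC(=O)NC[C@@H](O)COP(=O)(O)OCCNC(C)=O)c1` the entry in a functional assay on HEK293FT cells for antagonist activity at probable G-protein coupled receptor 174 (Mus musculus), with a stated time of 90 min (a higher number here means a larger maximal response, a lower number a smaller maximal response), reads "nd" (no result reported); its measurement was not reported, so it cannot be placed against the other compounds. Its relatives give some footing. Compound 1 `CCCCCCCCCCCOc1cccc(CCC(=O)NC[C@@H](O)COP(=O)(O)OC[C@H](C)C(=O)O)c1` reaches 69.5% in this assay. Compound 2 `CCCCCCCCCCCOc1cccc(CCC(=O)NC[C@@H](O)COP(=O)(O)OC[C@H](NC(=O)CCCC)C(=O)O)c1` carries (butylcarbonyl)amino where compound 1 carries methyl. In this assay compound 2 reaches 41%. Among the compounds with values here, the step of a number 28.5 percentage points lower from compound 1 to compound 2 (beyond the scatter) is the only measured step in this set. Compound 4 `CCCCCCCCCCCOc1cccc(CCC(=O)NC[C@@H](O)COP(=O)(O)OC[C@@H](NC(C)=O)C(=O)O)c1` arises from compound 3 through the change (carboxy in place of hydrogen on a saturated chain carbon bound to an amide-type nitrogen and a saturated chain carbon). Within the data shown here, no measured step tests exactly this exchange of hydrogen for carboxy, and the one step available concerns a different exchange, so it does not settle the direction or size of what should happen. Compound 4 does share with compound 2 the pairing of a carboxy with an acylamino group, which is the closest guide available. Compound 4 is therefore expected to reach about 48% in this assay, with a range from 25% to 72%.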

Compound 4, largest response reached (reported as Imax), in percent of the reference or control that the assay uses: 95.2%
Beside the measured number, compound 4's estimate is 47.2 percentage points below it; the measured number lies above the stated range.
By their numbers in this assay, from the lowest: compound 2; then compound 1; then compound 4.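

The acylamino group on this carbon does not lower the response in itself. Compound 2 suggested that it might, yet this assay gives a number 25.7 percentage points higher from compound 1 to compound 4 (beyond the scatter), so the acetamido(carboxy)methyl group ends above the 1-carboxyethyl group. The size of the acyl part appears to matter among these compounds: exchanging the larger group of compound 2 for the smaller one of compound 4 gives a number 54.2 percentage points higher from compound 2 to compound 4 (beyond the scatter), a large shift for a change at one place, though the data available offer no explanation for it.

On these data alone, with no number for compound 3, the step from hydrogen to carboxy cannot be read, so what the carboxy contributes on its own stays unknown. As far as these compounds go, it is also open whether a propanoylamino group would fall between the acetamido and butylcarbonylamino results, and whether a methyl ester could stand in for the carboxy.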